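The source may hold more compounds than are shown below. What is called first, only, known or untested is meant among the compounds shown, and "the series" means these compounds.

In a functional assay on the whole organism (strain Wistar Albino) for inhibition, with Rattus norvegicus as the target, read by paw edema, with a stated time of 3 h, at a dose of 20 mg/kg (a higher number here means more inhibition at the dose given (going by the name of the read-out), a lower number less inhibition), the three measured compounds stand as follows:

compound 1, `Cc1occc1-c1nnc2sc(-c3ccnc(Cl)c3)nn12`: 24.1%
compound 2, `COc1ccc(Cl)c(-c2nnc3n2NC(c2ccco2)S3)c1`: 23.1%
compound 3, `COc1ccc(Cl)c(-c2nnc3n2NC(c2ccc([N+](=O)[O-])o2)S3)c1`: 21.7%

Compound 3 carries the lowest number of the three, but compound 2 and compound 1 both sit within the scatter of it, so no ordering among the three can be read from these numbers.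

Compound 4, `COc1ccc(Cl)c(-c2nnc3n2NC(c2ccc[nH]2)S3)c1`, differs from compound 3 in one place: 1H-pyrrol-2-yl in place of 5-nitrofuran-2-yl on a saturated ring carbon. For the measured compounds named here, only one measured step touches this part of the structure, the step of a number 1.4 percentage points lower from compound 2 to compound 3 (within the scatter), which removed nothing and added the nitro group at the aromatic carbon; it did not move the read-out beyond the scatter. Going by the values given here, the step to compound 4 reverses that addition and also exchanges the furan ring for a pyrrole ring, for which no measured pair exists. Given that the only relevant step stayed within the scatter, no movement beyond the scatter is expected for compound 4 in this assay. The expected step is a number 1.3 percentage points higher from compound 3 to compound 4 (within the scatter). Compound 4 is estimated at 23%, in the range 13% to 33%.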

Compound 4, a percentage reported as inhibition, in the whole organism at one dose (the size of the read-out at that dose, not a potency): 18.4%
For compound 4 the middle estimate is 4.6 percentage points above the measured one; low and high end bracket the measured number.
By their numbers in this assay, from the lowest: compounds 4, 3, 2 and 1 (each within the scatter of the next).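

In this assay the saturated ring carbon next to the ring sulfur now carries a third group, and an exchange of the ring itself can be read: 1H-pyrrol-2-yl in place of 5-nitrofuran-2-yl gives a number 3.3 percentage points lower from compound 3 to compound 4 (within the scatter) and 1H-pyrrol-2-yl in place of furan-2-yl gives a number 4.7 percentage points lower from compound 2 to compound 4 (within the scatter) in the same series. Both steps lie within the scatter, so neither the pyrrole ring with its hydrogen-bond donor nor the absence of the nitro group separates these compounds at this position. Nothing measured here offers an explanation for these numbers.

Open, as far as these compounds go, is whether a non-aromatic group on this carbon, such as an amine, a carboxylic acid or a longer chain, would move the read-out beyond the scatter. Also open, from the compounds shown here alone, is whether any group at this position would do so at another dose or time.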